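Hydroxymethyl to methyl on the core of compound 1

The source may report more compounds than this note shows. Statements on the series, on what has been measured and on what is new or still open speak of the compounds shown alone.

Within the data shown here, compound 1 (`CNC(=O)c1cc(C(=O)N[C@H]2[C@@H]3COC[C@@H]32)cc2c1OC[C@@]2(CO)c1ccccc1`) gives 2.4 in a physicochemical assay for lipophilicity, at pH 7.4 (on this read-out higher numbers stand for higher lipophilicity and lower numbers for lower lipophilicity), and holds the lower of the two numbers so far. Compound 2 (`CNC(=O)c1cc(C(=O)N[C@H]2[C@@H]3COC[C@@H]32)cc2c1O[C@H](CF)[C@H]2c1ccccc1`) gives 3.6 in this assay and stands higher, beyond the scatter. Compound 2 differs from compound 1 in more than one place, so this gap does not size the next change.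

Compound 3 (`CNC(=O)c1cc(C(=O)N[C@H]2[C@@H]3COC[C@@H]32)cc2c1OC[C@@]2(C)c1ccccc1`) has not yet been measured. Compared with compound 1, it carries the change (hydrogen in place of hydroxy on a saturated chain carbon bound to a saturated ring carbon) of hydrogen in place of hydroxy on a saturated chain carbon bound to a saturated ring carbon, which also reads as hydroxymethyl to methyl.

Among the measured compounds shown here, no measured pair shows this change, so the expectation rests on the structural change alone. The estimated step (a number 0.90 log units higher from compound 1 to compound 3 (beyond the scatter)) is expected to be upward and beyond the scatter. Compound 3 is expected at 3.3 (estimated range 2.9 to 3.7).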

Compound 3, distribution coefficient: 3.7
The estimate for compound 3 lay 0.40 log units below the measured number, and the stated range covers the measured number.
By their numbers in this assay, from the lowest: compound 1; then compounds 2 and 3 (each within the scatter of the next).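

With hydrogen in place of hydroxy on a saturated chain carbon bound to a saturated ring carbon, this assay now has a step that belongs to one change alone (a number 1.30 log units higher from compound 1 to compound 3 (beyond the scatter)), and this step is large. The gap to compound 2 spans more than one place, whereas this result shows that the read-out responds strongly to this single change on the core of compound 1. No measurement on hand gives a cause for the size of this step.

Only one replacement at this position is shown, so where an aminomethyl, a methoxymethyl or a carboxylic acid would fall relative to compound 1 and compound 3 stays open. From the compounds shown here alone, whether hydroxymethyl to methyl gives a step of similar size on another core also stays open.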